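Same Benzyl Swap, Applied on a Second Core

A few compounds are considered here, and "the series" means these few. Any claim that something is new, unique, unknown or untested is made for them only; others in the source may bear on it.

Compound 2 `COc1ccc(F)cc1CNCCCNc1ccnc2cc(Cc3cccc(C(F)(F)F)c3)ccc12` carries a 5-fluoro-2-methoxyphenyl group on a saturated chain carbon bound to an amine nitrogen. In a physicochemical assay for solubility, with a stated time of 18 h, at pH 7.4 (on this read-out higher numbers stand for higher solubility and lower numbers for lower solubility), compound 2 gives 4200 nM. Compound 1 `COc1cccc(CNCCCNc2ccnc3cc(Cc4cccc(C(F)(F)F)c4)ccc23)c1O` differs from it by 2-hydroxy-3-methoxyphenyl in place of 5-fluoro-2-methoxyphenyl on a saturated chain carbon bound to an amine nitrogen, and in this assay compound 1 gives 4200 nM, so the step reads no change at the digits printed from compound 2 to compound 1 (within the scatter). Compound 3 `COc1ccc(F)cc1CNCCCNc1ccnc2cc(CCc3ccccc3)ccc12` keeps the amine-side group of compound 2 but differs in the core by benzyl in place of 3-(trifluoromethyl)phenyl on a saturated chain carbon bound to an aromatic carbon. In this assay compound 3 gives 4200 nM, a step of no change at the digits printed from compound 2 to compound 3 (within the scatter). Compound 4 `COc1cccc(CNCCCNc2ccnc3cc(CCc4ccccc4)ccc23)c1O` has not yet been measured. For the measured compounds named here, it differs from compound 3 by 2-hydroxy-3-methoxyphenyl in place of 5-fluoro-2-methoxyphenyl on a saturated chain carbon bound to an amine nitrogen, the same change at the same place as the one that turns compound 2 into compound 1. That earlier instance left the read-out flat in no change at the digits printed from compound 2 to compound 1 (within the scatter), and the core swap in no change at the digits printed from compound 2 to compound 3 (within the scatter) was flat as well. On that basis the step is expected to be no change at the digits printed from compound 3 to compound 4 (within the scatter). Compound 4 is therefore estimated at 4200 nM, expected to fall between 2100 nM and 8400 nM. This expectation rests on a single prior instance of the change, so it remains a guess until the measurement is in.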

Compound 4, solubility: 4200 nM
Compound 4: the middle estimate sits on the measured number at the digits printed; the measured number falls inside the stated range.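

For the compounds shown here, the swap to 2-hydroxy-3-methoxyphenyl reads the same on both cores, with no change at the digits printed from compound 2 to compound 1 (within the scatter) on the first and no change at the digits printed from compound 3 to compound 4 (within the scatter) on the second, and the core change reads the same with either amine-side group, with no change at the digits printed from compound 2 to compound 3 (within the scatter) and no change at the digits printed from compound 1 to compound 4 (within the scatter) as its two instances. In this assay, going by these compounds alone, this shows only that neither change separates these four compounds; two flat instances of each change make no general rule, and they do not show how either change would behave on a core outside this set. Nothing measured here explains why the four values coincide.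

From the compounds shown here alone, all four compounds print one shared value, and it remains open whether any other change to this series would give a different one. A carboxylic acid in place of the methoxy group, or a longer chain on the amine nitrogen, could show whether the flat readings hold beyond these groups.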